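The compounds below may be only part of what the source reports. "The series", "measured", "known", "first", "only" and "open" are said of these compounds alone.

Three compounds, sharing one core, have been measured in a functional assay on CHO cells for antagonist activity at sphingosine 1-phosphate receptor 2 (Homo sapiens), read by calcium flux; on this read-out higher numbers stand for weaker inhibition and lower numbers for stronger inhibition. Compound 1, with the structure `O=C(O)Cn1nc(CC(=O)Nc2ccc(OC(F)(F)F)c(Cl)c2)c2ccccc2c1=O`, gives 389 nM in this assay, which places it second highest of the three numbers. The lowest number belongs to compound 2, `O=C(O)Cn1nc(Cc2nc3cc(Cl)c(OCC(F)F)cc3[nH]2)c2ccccc2c1=O`, which gives 12 nM in this assay, a gap to compound 1 that lies beyond the scatter. The highest belongs to compound 3, `COc1cc(OC)c(NC(=O)Cn2nc(CC(=O)O)c3ccccc32)cc1Cl`, which gives 3360 nM in this assay, again beyond the scatter from compound 1.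

Among the measured compounds shown here, no pair of these three differs in only one place, so no single step between measured compounds can be drawn on. The next compound to be measured is compound 4, `CCn1nc(CC(=O)Nc2ccc(OC(F)(F)F)c(Cl)c2)c2ccccc2c1=O`. It differs from compound 1 in one place: methyl in place of carboxy on a saturated chain carbon bound to an aromatic nitrogen. The change removes a carboxy group bearing one hydrogen-bond donor and one acceptor and puts a plain methyl in its place, so that the carboxymethyl on the aromatic nitrogen becomes an ethyl.

With nothing measured on this exact change, the expectation rests on compound 1 alone. Compound 4 is expected to inhibit more weakly than compound 1 in this assay, with an expected step of a 7.7-fold higher number from compound 1 to compound 4 (0.89 log units; beyond the scatter). The estimate for compound 4 in this assay is 3000 nM, expected to fall between 600 nM and 15000 nM.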

Compound 4, half-maximal inhibitory concentration in the sphingosine 1-phosphate receptor 2 assay: 199 nM
Estimate against measurement, compound 4: 15-fold (1.18 log units) above; measured number outside the range, below it.
By their numbers in the sphingosine 1-phosphate receptor 2 assay, from the lowest: compound 2; then compounds 4 and 1 (each within the scatter of the next); then compound 3.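

In the sphingosine 1-phosphate receptor 2 assay, the change from carboxymethyl to ethyl gives a 2.0-fold lower number from compound 1 to compound 4 (0.29 log units; within the scatter), so on the core of compound 1 inhibition does not depend on keeping the carboxy group at this position. In a physicochemical assay for lipophilicity, at pH 7.4 (a higher number here means a more lipophilic compound, a lower number a more polar compound), compound 1 gives 2.92 and compound 4 gives 5.42, a large shift for the same single change. Lipophilicity therefore moves far beyond the scatter while inhibition stays within it, a separation between the two read-outs that no other pair shown could reveal: the measured distribution coefficient of compound 1, 2.92, and of compound 4, 5.42, a number 2.50 log units higher (beyond the scatter)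

On these data alone, this rests on a single pair, so it remains unknown whether the carboxy group can be replaced as freely in compound 2 or compound 3, which carry different groups elsewhere on their structures. As far as these compounds go, it is also open how an amine, a hydroxyl or a longer chain in place of the carboxy group would behave in the sphingosine 1-phosphate receptor 2 assay, and whether any of them would give a number in the physicochemical assay closer to that of compound 1 while keeping inhibition.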